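A few compounds are considered here, and "the series" means these few. Any claim that something is new, unique, unknown or untested is made for them only; others in the source may bear on it.

Measured compounds:
- compound 1 `CCCOC(=O)c1c(C)coc1-c1ccc2c(CC)cccc2c1OC` in a functional assay on ZR-75-1 cells (Homo sapiens) for cytotoxicity, read by MTT assay, with a stated time of 72 h (on this read-out lower numbers stand for an effect already at smaller amounts and higher numbers for an effect only at larger amounts of compound), gives > 10 ug/mL, a limit of the assay and not a number.
- compound 2 `CCc1cccc2c(OC)c(-c3occ(C)c3CO)ccc12` gives in this assay > 10 ug/mL, again a limit and not a number.
- compound 3 `CCc1cccc2c(OC)c(-c3occ(C)c3CBr)ccc12` gives in this assay 4.6 ug/mL.

Compound 1 therefore stands only at a limit; of the three values shown, two sit at that same limit of > 10 ug/mL in this assay, at which 2 of the 3 values shown sit, and only compound 3 carries a number. Compound 4 `CCc1cccc2c(OC)c(-c3occ(C)c3COC(C)=O)ccc12` has not been measured. Against compound 1 the change is acetoxymethyl in place of propoxycarbonyl on an aromatic carbon.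

Two measured steps start from compound 1. The step that the two limits leave unreadable from compound 1 to compound 2 cannot be sized, since both ends sit at the limit. For the measured compounds named here, the step of an at least 2.1-fold lower number from compound 1 to compound 3 (0.33 log units; beyond the scatter) is the only readable one, and the step of an at least 2.1-fold lower number from compound 2 to compound 3 (0.33 log units; beyond the scatter) is of the same size; in both cases the bromomethyl compound is the one that gives a number. Compound 4, with its acetoxymethyl, carries neither a bromomethyl nor the propoxycarbonyl, and the ester-to-ester change from compound 1 gives no readable precedent. Compound 4 is therefore expected to stay near the limit, with the step that the limit leaves unreadable from compound 1 to compound 4 expected to lie within the scatter or to be unreadable. The estimate for compound 4 in this assay is 15 ug/mL, with a range from 6 ug/mL to 40 ug/mL.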

Compound 4, concentration for half-maximal effect: 3.5 ug/mL
Compound 4: middle estimate off by 4.3-fold (0.63 log units), on the high side, outside the stated range (below it).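

At this position, on an aromatic carbon of a five-membered aromatic ring with 1 oxygen, a number in this assay is not tied to the bromomethyl group: acetoxymethyl in place of propoxycarbonyl gives an at least 2.8-fold lower number from compound 1 to compound 4 (0.45 log units; beyond the scatter), so of these two esters only the acetoxymethyl compound leaves the limit. Acetyl in place of hydrogen on the oxygen of the hydroxymethyl group also gives a readable change, an at least 2.8-fold lower number from compound 2 to compound 4 (0.45 log units; beyond the scatter), where the earlier compounds offered no readable step for an oxygen-linked group on this carbon. Acetoxy and bromo on the same chain carbon cannot be told apart, with a 1.3-fold lower number from compound 3 to compound 4 (0.12 log units; within the scatter), so compound 3 and compound 4 stand level in this assay.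

The compounds shown do not tell whether the acetyl group itself matters or whether other groups on this chain carbon, such as an amine, a carboxylic acid or a longer acyloxy chain like butyryloxy, would also give a number. The steps that start from compound 1 and compound 2 also stay open-ended in size, since each of those two compounds gives only a limit and not a number: the limit of > 10 ug/mL in this assay, at which 2 of the 4 values shown sit.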